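Fluoro for chloro on the benzyl group: cytotoxicity limits

This account rests on a few compounds, and the source may have more. Where it says the series, first, only, none or still open, it means among the compounds named here.

Measured in an ADME assay on MT4 cells (Homo sapiens) for cytotoxicity, read by MTT assay (on this read-out lower numbers stand for higher toxicity in this test and higher numbers for lower toxicity in this test), so far:
- Compound 1 `Cc1c(Cc2c(F)cccc2F)nc(SCc2ccccn2)[nH]c1=O` gives > 70000 nM (a limit)
- Compound 2 `Cc1c(Cc2c(F)cccc2F)nc(SCc2ccncc2)[nH]c1=O` gives > 70000 nM (a limit)
- Compound 3 `Cc1c(Cc2c(F)cccc2Cl)nc(SCC(=O)c2ccccc2)[nH]c1=O` gives > 12000 nM (a limit)

Compound 3 has no number, only a limit, and stands at the limit of > 12000 nM in this assay, at which 1 of the 3 values shown sits, in a set where the other two values are limits as well. Compound 4 `Cc1c(Cc2c(F)cccc2F)nc(SCC(=O)c2ccccc2)[nH]c1=O` carries fluoro in place of chloro on an aromatic carbon, turning 2-chloro-6-fluorobenzyl into 2,6-difluorobenzyl (fluoro in place of chloro on an aromatic carbon).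

Going by the values given here, no measured step covers this change. Among the compounds with values here, the one step available, a step that the two limits leave unreadable from compound 1 to compound 2 (pyridin-4-yl in place of pyridin-2-yl), has no readable size and concerns a different group. The nearest support is indirect. Compound 1 carries the same 2,6-difluorobenzyl group and its > 70000 nM is a limit. Compound 2 also carries that group and its > 70000 nM is a limit.

No step beyond the usual scatter is therefore expected in this assay and no direction can be named. The expected step is a step that the limit leaves unreadable from compound 3 to compound 4 and it remains an estimate set against a limit. For compound 4 the estimate is 20000 nM with an expected range of 9000 nM to 80000 nM and most likely a limit rather than a number.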

Compound 4, half-maximal cytotoxic concentration: 65000 nM
Compound 4: middle estimate off by 3.3-fold (0.51 log units), on the low side, and the stated range covers the measured number.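

In this assay, going by these compounds alone, compound 4 gives 65000 nM, the only value so far that is a number rather than a limit, so the 2,6-difluorobenzyl series now has a measured cytotoxicity reading with benzoyl on the chain carbon bound to the sulfur. Compound 3 remains a limit, so the change from 2-chloro-6-fluorobenzyl to 2,6-difluorobenzyl has no readable size, and the step between compound 1 and compound 2 is likewise unreadable: the limit of > 12000 nM in this assay, at which 1 of the 4 values shown sits. Replacing either pyridyl group with benzoyl gives an at least 1.0-fold lower number from compound 2 to compound 4 (0.03 log units; that floor lies within the scatter) and an at least 1.0-fold lower number from compound 1 to compound 4 (0.03 log units; that floor lies within the scatter); both floors lie within the scatter, so they establish no real difference between benzoyl and either pyridyl group.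

On these data alone, whether fluoro in place of chloro on this aromatic carbon moves the cytotoxicity at all remains open, as the chloro member of the pair has only a limit. Also open, as far as these compounds go, is how this read-out responds to a bromo or methyl group at the same aromatic carbon, or to an amine or a carboxylic acid in place of benzoyl on the chain.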